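The compounds below may be only part of what the source reports. "The series", "measured", "known", "first", "only" and "open" are said of these compounds alone.

Measured so far in an assay on isolated protein for inhibition of DNA topoisomerase 1 (Homo sapiens), with a stated time of 30 min, tested at 20 uM; a higher number here means a stronger effect of the compound at the concentration tested, a lower number a weaker effect:
compound 1 `Cc1ccc2nc(-c3cccc(F)c3)[nH]c(=O)c2c1` — 0.2%
compound 2 `CN(C)c1ccc2nc(-c3cccc4ccccc34)[nH]c(=O)c2c1` — 2.4%
compound 3 `CCN(CC)c1ccc2nc(-c3ccccc3C(F)(F)F)[nH]c(=O)c2c1` — 13.3%

Compound 1 stands lowest of the three numbers in this assay. For the measured compounds named here, its nearest neighbour is compound 2, whose number sits within the usual scatter of the one for compound 1, so the two cannot be ordered. Compound 3 stands furthest away, and that gap lies beyond the scatter.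

The next compound is compound 4 `Cc1ccc2nc(-c3cccc(C(F)(F)F)c3)[nH]c(=O)c2c1`, which differs from compound 1 in one place: trifluoromethyl in place of fluoro on an aromatic carbon. Going by the values given here, no pair of measured compounds differs in this single change, so the size of the step has to be judged from the values alone.

Compound 4 is expected to give 4%, with a range from 0% to 15%. The expected step is a number 3.8 percentage points higher from compound 1 to compound 4 (within the scatter), upward but not clearly beyond the scatter. Any expectation of a rise rests only on the fact that compound 3, which also carries a trifluoromethyl group, gives 13.3% in this assay, and that compound has a different group on the shared core as well, so the comparison is loose.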

Compound 4, a percentage reported as inhibition, at one concentration (the size of the read-out at that concentration, not a potency): 4.2%
For compound 4 the middle estimate is 0.2 percentage points below the measured one; low and high end bracket the measured number.
By their numbers in this assay, from the lowest: compounds 1, 2, 4 and 3 (each within the scatter of the next, the first and the last beyond it).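

In this assay, trifluoromethyl in place of fluoro on an aromatic carbon, meta to a large group, gives a number 4 percentage points higher from compound 1 to compound 4 (within the scatter). For the compounds shown here, this is the first single change that can be read, and on the shared core it separates the two groups by no more than the scatter, although trifluoromethyl brings in more heavy atoms. The step applies only to this position and this core, and it cannot be carried over to compound 3, which differs from compound 4 in more than one place. Nothing measured here gives a reason for the size of this step.

Open, as far as these compounds go, is whether a nitrile or a carboxylic acid in place of fluoro on this aromatic carbon would read apart from compound 1. Also open, from the compounds shown here alone, is whether the change from fluoro to trifluoromethyl gives a similar step when a diethylamino group replaces the methyl on the core.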